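This account rests on a few compounds, and the source may have more. Where it says the series, first, only, none or still open, it means among the compounds named here.

Working notes on the series, read in an ADME assay on MIA PaCa-2 cells (Homo sapiens) for cytotoxicity, read by MTT assay, with a stated time of 72 h; on this read-out lower numbers stand for stronger inhibition and higher numbers for weaker inhibition. Compound 1 (`COc1ccc(C2=C(c3cc(OC)c(OC)c(OC)c3)C(=O)C(OC(C)=O)C2)cc1`) gives < 1 ug/mL, which is a limit of the assay and not a number. Among the measured compounds shown here, compound 2 (`COc1ccc(C2=C(c3cc(OC)c(OC)c(OC)c3)C(=O)C(OC(C)=O)C2)cc1F`) gives 39.5 ug/mL, the only true number so far, so no ranking among measured numbers is possible yet. For the measured compounds named here, the one measured step, an at least 39-fold higher number from compound 1 to compound 2 (1.59 log units; beyond the scatter), puts compound 2 well on the weak side. The other end of the scale is marked by the limit of < 1 ug/mL in this assay, at which 1 of the 2 values shown sits.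

Compound 3 (`COc1ccc(C2=C(c3cc(OC)c(OC)c(OC)c3)C(=O)C(OC(C)=O)C2)cc1O`) carries hydroxy in place of fluoro on an aromatic carbon, 3-fluoro-4-methoxyphenyl becoming 3-hydroxy-4-methoxyphenyl: hydroxy in place of fluoro on an aromatic carbon. Going by the values given here, only one measured step bears on this aromatic carbon, and the loss in an at least 39-fold higher number from compound 1 to compound 2 (1.59 log units; beyond the scatter) came with fluoro entering, which now leaves. That step gives no direct reading for hydroxy, so recovery of only part of the loss is the cautious expectation, and a report as a limit remains possible.

The step expected in this assay is a large one toward stronger inhibition, estimated as a 13-fold lower number from compound 2 to compound 3 (1.12 log units; beyond the scatter). For compound 3 the expected value is 3 ug/mL, with an estimated range of 0.4 ug/mL to 30 ug/mL.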

Compound 3, half-maximal inhibitory concentration: 18.5 ug/mL
For compound 3 the middle estimate is 6.2-fold (0.79 log units) below the measured one; low and high end bracket the measured number.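

In this assay, hydroxy in place of fluoro on this aromatic carbon gives a 2.1-fold lower number from compound 2 to compound 3 (0.33 log units; beyond the scatter), so the identity of the group here makes a measurable but modest difference. Against hydrogen at the same carbon, hydroxy still gives an at least 18-fold higher number from compound 1 to compound 3 (1.26 log units; beyond the scatter), which shows that the large loss is not confined to fluoro: both groups tested on this carbon, ortho to a methoxy group, sit well on the weak side of compound 1. Compound 1 stands at a limit and not at a number, so the full size of the loss from hydrogen cannot be read: the limit of < 1 ug/mL in this assay, at which 1 of the 3 values shown sits.

From the compounds shown here alone, whether an amine or a methyl group on this carbon would stay close to hydrogen or fall with fluoro and hydroxy remains open. Also open, going by these compounds, is whether the same replacements would read alike on the shared core if other parts of it were changed, since all three compounds differ only at this one carbon.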